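The source may report more compounds than this note shows. Statements on the series, on what has been measured and on what is new or still open speak of the compounds shown alone.

Compound 1 `Oc1cccc(-c2cc(-c3ccc(F)cc3)cc(-c3cccc(O)c3)n2)c1` has been measured in a functional assay on HCT-15 cells (Homo sapiens) for inhibition (a higher number here means a weaker inhibitor, a lower number a stronger inhibitor), where compound 1 gives 6310 nM. Of the two numbers recorded so far this is the highest, and the nearest is compound 2 `Oc1ccc(-c2cc(-c3ccc(F)cc3)cc(-c3cccc(O)c3)n2)cc1`, which in this assay gives 5020 nM; the step of a 1.3-fold lower number from compound 1 to compound 2 (0.10 log units; within the scatter) lies within the scatter. Compound 3 `Oc1cccc(-c2cc(-c3ccc(C(F)(F)F)cc3)cc(-c3cccc(O)c3)n2)c1` differs from compound 1 by trifluoromethyl in place of fluoro on an aromatic carbon; cut one bond further out, a 4-fluorophenyl becomes a 4-(trifluoromethyl)phenyl. Among the compounds with values here, no measured step touches this part of the shared core. Within the data shown here, the only recorded step, a 1.3-fold lower number from compound 1 to compound 2 (0.10 log units; within the scatter), concerns a hydroxyphenyl group on another part of the core and gives no guidance for an exchange on the fluorophenyl ring. Compound 3 is therefore expected to stay in the region of the measured pair, with no direction beyond the scatter assumed. The estimate for compound 3 in this assay is 5000 nM, expected within a range from 1500 nM to 16000 nM, which means an expected step of a 1.3-fold lower number from compound 1 to compound 3 (0.10 log units; within the scatter).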

Compound 3, half-maximal inhibitory concentration: > 50000 nM
Compound 3: only a limit was reported; the forecaster's own chance of this, stated with the estimate: 5%; middle value at least 10-fold (1.00 log units) away from the limit.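

Within the data shown here, the 4-fluorophenyl part of the shared core, which no earlier step had touched, proves sensitive in this assay: the exchange to 4-(trifluoromethyl)phenyl gives an at least 7.9-fold higher number from compound 1 to compound 3 (0.89 log units; beyond the scatter). This one change therefore counts for more than the move of the hydroxyl group on the hydroxyphenyl ring, which gave a 1.3-fold lower number from compound 1 to compound 2 (0.10 log units; within the scatter). Compound 3 is reported only as a limit, so the full size of its step remains unknown: the limit of > 50000 nM in this assay, at which 1 of the 3 values shown sits.

The compounds shown leave open whether chloro, methyl or methoxy in this place, or plain hydrogen, would stay near compound 1 or weaken inhibition as trifluoromethyl does. They also leave open whether the same exchange would have a similar effect on compound 2, which carries a 4-hydroxyphenyl group.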